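Replacing the aryl group on the carbon double-bonded to nitrogen

The compounds below may be only part of what the source reports. "The series", "measured", "known", "first", "only" and "open" are said of these compounds alone.

Of the compounds shown here, three sharing one core have been tested in a functional assay on L1210 cells (Mus musculus) for antiproliferative activity, read by CCK-8 assay; a lower number here means a stronger inhibitor, a higher number a weaker inhibitor. Compound 1 `C(=N/c1nnc(SCc2c[se]c(-c3ccccc3)n2)s1)\c1ccccc1` carries a plain phenyl on the carbon with a double bond to nitrogen, and in this assay compound 1 gives 46500 nM. Compound 2 `Oc1ccc(/C=N/c2nnc(SCc3c[se]c(-c4ccccc4)n3)s2)cc1` adds a hydroxy group on that ring; in this assay compound 2 reaches only the limit > 100000 nM, which is a boundary of the measurement and not a number. Compound 3 `COc1cc(/C=N/c2nnc(SCc3c[se]c(-c4ccccc4)n3)s2)ccc1O` carries a 4-hydroxy-3-methoxyphenyl, and in this assay compound 3 likewise stops at the limit > 100000 nM, again not a number. The step of an at least 2.1-fold higher number from compound 1 to compound 2 (0.33 log units; beyond the scatter) and the step of an at least 2.1-fold higher number from compound 1 to compound 3 (0.33 log units; beyond the scatter) both point toward weaker inhibition, while the step that the two limits leave unreadable from compound 2 to compound 3 cannot be read because both values sit at the limit of > 100000 nM in this assay, at which 2 of the 3 values shown sit.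

Compound 4 `CN(C)c1ccc(/C=N/c2nnc(SCc3c[se]c(-c4ccccc4)n3)s2)cc1` differs from compound 3 by 4-(dimethylamino)phenyl in place of 4-hydroxy-3-methoxyphenyl on a carbon with a double bond to nitrogen. Within the data shown here, no measured step covers this exchange; the nearest is the step of an at least 2.1-fold higher number from compound 1 to compound 3 (0.33 log units; beyond the scatter), which shows that the group now leaving made compound 3 weaker than compound 1. Going by these compounds, removing it may pull the number back toward compound 1, but the effect of the entering group is unknown. The estimate for compound 4 is therefore 80000 nM, with an expected range from 30000 nM to 200000 nM and a fair chance of only a limit. This means an expected step of an at least 1.2-fold lower number from compound 3 to compound 4 (0.09 log units; that floor lies within the scatter).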

Compound 4, half-maximal inhibitory concentration: > 100000 nM
Compound 4 gave a limit, no number; the forecaster's own chance of this, stated with the estimate: 45%; middle value at least 1.2-fold (0.09 log units) away from the limit.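

The result extends the earlier picture to a group of a different kind. In this assay, the plain phenyl of compound 1 gives way to a 4-(dimethylamino)phenyl with an at least 2.1-fold higher number from compound 1 to compound 4 (0.33 log units; beyond the scatter), the same direction as the two hydroxy-bearing rings, so among the compounds shown, every substituted ring at this carbon is weaker than plain phenyl and none goes against that pattern. The 4-(dimethylamino)phenyl counts 0 hydrogen-bond donors where the 4-hydroxy-3-methoxyphenyl counts 1, so a hydroxy group on the ring is not required for this loss of activity. The steps among compound 2, compound 3 and compound 4 cannot be read, and no order can be given for these three, because each value is a limit and not a number: the limit of > 100000 nM in this assay, at which 3 of the 4 values shown sit.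

Still open, going by these compounds, is how small a substituent on this ring can be before activity falls away, for instance whether a single fluorine, chlorine or methyl group would keep a measurable value. On these data alone, it is also open whether any group at this carbon, such as a carboxylic acid on the ring or a longer alkyl chain in place of the ring, could improve on compound 1 at 46500 nM.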